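Cyclopentyl for Isopropyl on a Hydrazine Nitrogen

The compounds below may be only part of what the source reports. "The series", "measured", "known", "first", "only" and "open" are said of these compounds alone.

Compound 3 `Cc1ccccc1-c1nnc(N(C)NC(C)C)s1` gives 35 mg/kg in a functional assay on the whole organism with Mus musculus as the target, in the maximal electroshock model, with a stated time of 1 h (on this read-out higher numbers stand for an effect only at larger amounts of compound and lower numbers for an effect already at smaller amounts), the lowest of the two numbers available. Its nearest neighbour is compound 1 `Cc1ccccc1-c1nnc(N(C)N)s1`, which gives 75 mg/kg; the step of a 2.1-fold lower number from compound 1 to compound 3 (0.33 log units; beyond the scatter) is a modest gain. Compound 2 `Cc1ccccc1-c1nnc(NNC2CCCC2)s1` reaches only the limit > 100 mg/kg, not a number. Compound 4 `Cc1ccccc1-c1nnc(N(C)NC2CCCC2)s1` differs from compound 3 by cyclopentyl in place of isopropyl on an amine nitrogen. Among the compounds with values here, only the step of a 2.1-fold lower number from compound 1 to compound 3 (0.33 log units; beyond the scatter) bears on this position, and it is small, so no change beyond the scatter is expected. Compound 4 is therefore estimated at 45 mg/kg, within a range from 20 mg/kg to 110 mg/kg. The expected step of a 1.3-fold higher number from compound 3 to compound 4 (0.11 log units; within the scatter) is thus a slight one.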

Compound 4, dose for half-maximal effect: 110 mg/kg
For compound 4 the middle estimate is 2.4-fold (0.39 log units) below the measured one, within the range that was stated.
By their numbers in this assay, from the lowest: compound 3; then compounds 1 and 4 (each within the scatter of the next).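

In this assay, the group on this amine nitrogen clearly matters, with a 3.1-fold higher number from compound 3 to compound 4 (0.50 log units; beyond the scatter) when cyclopentyl replaces isopropyl. Cyclopentyl in place of hydrogen makes no change beyond the scatter, a 1.5-fold higher number from compound 1 to compound 4 (0.17 log units; within the scatter), so among these compounds only the isopropyl of compound 3 lowers the number. Compound 2 has a limit rather than a number, so its step to compound 4 cannot be read: the limit of > 100 mg/kg in this assay, at which 1 of the 4 values shown sits.

Open, going by these compounds, is where an ethyl, a cyclopropyl or a phenyl group on this nitrogen would fall, and so whether the gain depends closely on isopropyl itself.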